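From Pyrrolidin-1-yl to Diethylamino: an Unmeasured Analogue

A few compounds are considered here, and "the series" means these few. Any claim that something is new, unique, unknown or untested is made for them only; others in the source may bear on it.

Of the compounds shown here, three have been measured in a functional assay on B16 cells (Mus musculus) for cytotoxicity, read by MTT assay, with a stated time of 72 h; a higher number here means a weaker inhibitor, a lower number a stronger inhibitor. Compound 1 `COc1c(OCCCCN2CCN(C)CC2)cc(O)c2c(=O)cc(-c3ccc(Cl)cc3)oc12` gives 2090 nM in this assay, compound 2 `COc1c(OCCCCN2CCN(C)CC2)cc(O)c2c(=O)cc(-c3ccc(Br)cc3)oc12` gives 4330 nM, and compound 3 `O=c1cc(-c2ccccc2)oc2c(OCCCN3CCCC3)c(OCc3ccccc3)cc(O)c12` gives 7980 nM. Among the compounds with values here, the only step within this set that changes a single place is a 2.1-fold higher number from compound 1 to compound 2 (0.32 log units; beyond the scatter), a swap of bromo in place of chloro on an aromatic carbon. Compound 3 carries the highest number of the three; its gap to compound 2 lies within the scatter, while its gap to compound 1 lies beyond it.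

Compound 4 `CCN(CC)CCCCOc1c(OCc2ccccc2)cc(O)c2c(=O)cc(-c3ccccc3)oc12` has not yet been measured. It differs from compound 3 by (diethylamino)methyl in place of pyrrolidin-1-yl on a saturated chain carbon, three bonds along the chain from an oxygen on an aromatic ring. Within the data shown here, no measured step bears on this change: the single-place step between compound 1 and compound 2 concerns a halogen on an aromatic ring and says nothing about the amine, and compound 3 has no measured partner that differs from it only in the amine. With nothing in the data pointing in either direction, the step of a 1.0-fold higher number from compound 3 to compound 4 (0.00 log units; within the scatter) is expected to stay within the scatter. Compound 4 is therefore estimated at 8000 nM in this assay, with an expected range from 3000 nM to 21000 nM.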

Compound 4, half-maximal inhibitory concentration: 4880 nM
Estimate against measurement, compound 4: 1.6-fold (0.21 log units) above, within the range that was stated.
By their numbers in this assay, from the lowest: compound 1; then compounds 2, 4 and 3 (each within the scatter of the next).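

In this assay, within the data shown here, the step of a 1.6-fold lower number from compound 3 to compound 4 (0.21 log units; within the scatter) gives the first reading at the amine end of the side chain, since the only earlier step concerned a halogen on an aromatic carbon. Cut one bond further out, the change reads 3-(pyrrolidin-1-yl)propyl to 4-(diethylamino)butyl, so the open diethylamino group and the longer chain arrive together, and the pair shows only that the two changes combined leave the number within the scatter, without saying what either does alone. No evidence available here bears on this result.

A 4-(pyrrolidin-1-yl)butyl or a 3-(diethylamino)propyl chain on the same core would separate the amine from the chain length, which compound 3 and compound 4 alone cannot do. From the compounds shown here alone, whether a piperidine or morpholine ring in the amine's place, or a shorter 2-(diethylamino)ethyl chain, would move the number beyond the scatter also stays open, as does whether the reading at this position holds with a chloro or bromo group on the aromatic ring.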